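This account rests on a few compounds, and the source may have more. Where it says the series, first, only, none or still open, it means among the compounds named here.

Three compounds share one core and differ only in the group on the oxygen next to the carbonyl group of the ester. Compound 1 `CCOC(=O)/C=C(C)/C=C/CC(C)CCCC(C)(C)OC` carries an ethyl group there; in a physicochemical assay for lipophilicity (a higher number here means a more lipophilic compound, a lower number a more polar compound), compound 1 gives 5.54. Compound 2 `CCCCOC(=O)/C=C(C)/C=C/CC(C)CCCC(C)(C)OC` carries a butyl group, and in this assay compound 2 gives 6.62. Compound 3 `C#CCOC(=O)/C=C(C)/C=C/CC(C)CCCC(C)(C)OC` carries a propargyl group; in this assay compound 3 gives 4.66, the lowest of the three values. The measured steps show how strongly this position sets the number: a number 1.08 log units higher from compound 1 to compound 2 (beyond the scatter), a number 0.88 log units lower from compound 1 to compound 3 (beyond the scatter) and a number 1.96 log units lower from compound 2 to compound 3 (beyond the scatter).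

Compound 4 `C=CC(C)OC(=O)/C=C(C)/C=C/CC(C)CCCC(C)(C)OC` has not yet been measured. It differs from compound 3 in one place: 1-methylprop-2-en-1-yl in place of propargyl on an oxygen next to a carbonyl group. The entering group has as many carbons as the butyl group of compound 2 but carries one double bond, while the leaving propargyl group carries a triple bond. Because compound 2 stands at 6.62 and compound 3 at 4.66, a large rise in this assay is expected for compound 4, though not all the way to compound 2. Compound 4 is therefore estimated at 5.9, within a range from 5.4 to 6.4, which means an expected step of a number 1.24 log units higher from compound 3 to compound 4 (beyond the scatter).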

Compound 4, partition coefficient: 5.94
The estimate for compound 4 lay 0.04 log units below the measured number; the range from low to high includes it.
By their numbers in this assay, from the lowest: compound 3; then compound 1; then compound 4; then compound 2.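

In this assay, this position also responds to a group that is neither saturated like butyl nor a triple-bond group like propargyl: swapping propargyl for 1-methylprop-2-en-1-yl gives a large rise (a number 1.28 log units higher from compound 3 to compound 4 (beyond the scatter)). Within the data shown here, the new group stops short of butyl (a number 0.68 log units lower from compound 2 to compound 4 (beyond the scatter)) yet stands clear of ethyl (a number 0.40 log units higher from compound 1 to compound 4 (beyond the scatter)), so compound 4 falls inside the span of the earlier compounds and adds a fourth distinct level to the series. Nothing shown here explains these steps.

Compound 4 changes the double bond and the chain's shape together, so the share of each in the step cannot be separated. As far as these compounds go, how the number would respond to a longer chain such as hexyl, a benzyl group or a chain carrying an amine also remains open.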